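The source may hold more compounds than are shown below. What is called first, only, known or untested is meant among the compounds shown, and "the series" means these compounds.

Working notes on the series in an assay on CHO cells for displacement of a labelled ligand from adenosine receptor A1 (Homo sapiens), read by scintillation counting, with a stated time of 120 min, tested at 10 uM; on this read-out lower numbers stand for less inhibition and higher numbers for more inhibition at the one concentration tested (going by the name of the read-out). Compound 1 `CC(C)N1CCN(Cc2csc(N)c2C(=O)c2ccc(Cl)cc2)CC1` gives 0%. Compound 2 `Nc1scc(CN2CCN(c3ccc(F)cc3Cl)CC2)c1C(=O)c1ccc(Cl)cc1` gives 0%. Compound 3 `Nc1scc(CN2CCN(c3ccccc3C(F)(F)F)CC2)c1C(=O)c1ccc(Cl)cc1` gives 0%. Compound 2 therefore stands level with both neighbours: no change at the digits printed from compound 1 to compound 2 (within the scatter), no change at the digits printed from compound 2 to compound 3 (within the scatter), and likewise no change at the digits printed from compound 1 to compound 3 (within the scatter). Every exchange so far of the group on the amine nitrogen in the ring has left the read-out flat at the bottom of the scale.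

Compound 4 `Nc1scc(CN2CCN(c3ccc(Cl)c(C(F)(F)F)c3)CC2)c1C(=O)c1ccc(Cl)cc1` is not yet measured. It differs from compound 2 in one place: 4-chloro-3-(trifluoromethyl)phenyl in place of 2-chloro-4-fluorophenyl on an amine nitrogen in a ring. The three flat steps above are the ones that bear on this change, all of them within the scatter. The step expected is no change at the digits printed from compound 2 to compound 4 (within the scatter), none beyond the scatter. Compound 4 is estimated at 0%, with a range of -5% to 10%.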

Compound 4, a percentage reported as inhibition, at one concentration (the size of the read-out at that concentration, not a potency): 0%
Compound 4: middle estimate and measured number agree at the digits printed, within the range that was stated.
By their numbers in this assay, from the lowest: compounds 1, 2, 3 and 4 (each within the scatter of the next).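

The larger 4-chloro-3-(trifluoromethyl)phenyl, with 11 heavy atoms against 8 in 2-chloro-4-fluorophenyl, also leaves this assay flat (no change at the digits printed from compound 2 to compound 4 (within the scatter)), and the same reading holds against the other two groups (no change at the digits printed from compound 3 to compound 4 (within the scatter); no change at the digits printed from compound 1 to compound 4 (within the scatter)). A phenyl carrying both chloro and trifluoromethyl on this amine nitrogen therefore stays at the bottom of the scale too. No supporting measurement bears on this result.

As far as these compounds go, whether a carboxylic acid or a longer alkyl chain on this nitrogen would lift the read-out from the bottom of the scale remains open.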